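A few compounds are considered here, and "the series" means these few. Any claim that something is new, unique, unknown or untested is made for them only; others in the source may bear on it.

Working notes on the series. Compound 1 `COc1cc(OC)c(C(=O)/C=C/c2ccccc2SC)c(OC)c1` gives 8700 nM in a functional assay on NCI-H727 cells (Homo sapiens) for cytotoxicity, with a stated time of 48 h; on this read-out higher numbers stand for weaker inhibition and lower numbers for stronger inhibition. Compound 2 `COc1cccc(/C=C/C(=O)c2c(OC)cc(OC)cc2OC)c1` gives 8200 nM in this assay; the two cores differ as 3-methoxyphenyl in place of 2-(methylsulfanyl)phenyl on a double-bonded chain carbon bound to a double-bonded chain carbon, and the step is a 1.1-fold lower number from compound 1 to compound 2 (0.03 log units; within the scatter). Compound 3 `COc1cc(O)c(C(=O)/C=C/c2ccccc2SC)c(OC)c1` gives 9000 nM in this assay; the change from compound 1 is hydrogen in place of methyl on an oxygen on an aromatic ring, with a step of a 1.0-fold higher number from compound 1 to compound 3 (0.01 log units; within the scatter). Compound 4 `COc1cccc(/C=C/C(=O)c2c(O)cc(OC)cc2OC)c1` has not yet been measured in this assay; the change from compound 2 is hydrogen in place of methyl on an oxygen on an aromatic ring, the same change as from compound 1 to compound 3, made at the same kind of place and occurring twice among these compounds. Compound 4 is therefore expected to show a step of about a 1.0-fold higher number from compound 2 to compound 4 (0.02 log units; within the scatter) from compound 2, because a 1.0-fold higher number from compound 1 to compound 3 (0.01 log units; within the scatter) on the other core. Compound 4 is estimated at 8500 nM, between 4500 nM and 16000 nM.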

Compound 4, half-maximal inhibitory concentration: 14800 nM
Beside the measured number, compound 4's estimate is 1.7-fold (0.24 log units) below it; the range from low to high includes it.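

Methoxy to hydroxy on the aromatic ring gives a 1.8-fold higher number from compound 2 to compound 4 (0.26 log units; within the scatter) in this assay. Set beside the earlier step, the change shows no difference between the two cores: the same change on two cores in this assay, a 1.0-fold higher number (0.01 log units; within the scatter) from compound 1 to compound 3 and a 1.8-fold higher number (0.26 log units; within the scatter) from compound 2 to compound 4, 1.7-fold (0.24 log units) apart, within the scatter of two such steps This supports carrying the change between these two cores in this assay, but it rests on only two pairs, each step lies within the scatter, and it shows neither a real effect of the change on either core nor how the change would behave on any further core.

Open, on these data alone, is how a longer chain on that oxygen, such as ethyl in place of methyl, would read in this assay. Also open, as far as these compounds go, is how an amine in place of the hydroxy would read there.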